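This account rests on a few compounds, and the source may have more. Where it says the series, first, only, none or still open, it means among the compounds named here.

Measured compounds:
- compound 1, `CC(C)c1ccc2c(CNC(=O)CNS(=O)(=O)c3ccccc3)cc(C(=O)O)c-2cc1`, > 100000 nM in a functional assay on thoracic aorta for antagonist activity at thromboxane A2 receptor (Rattus norvegicus); a lower number here means a stronger inhibitor, a higher number a weaker inhibitor
- compound 2, `CC(C)c1ccc2c(CNC(=O)CNS(=O)(=O)c3ccc(Cl)cc3)cc(C(=O)O)c-2cc1`, > 100000 nM
- compound 3, `CC(C)c1ccc2c(CCC/C=N/N=C(\S)Nc3ccccc3)cc(C(=O)O)c-2cc1`, 590000 nM

In this assay compound 1 gives only a limit of the assay, not a number. Compound 2 likewise gives only a limit. For the measured compounds named here, compound 3 is the one compound with a number. The change from compound 1 to compound 2 is chloro in place of hydrogen on an aromatic carbon, and its step that the two limits leave unreadable from compound 1 to compound 2 cannot be read because of the limit of > 100000 nM in this assay, at which 2 of the 3 values shown sit. The difference between the cores of compound 1 and compound 3 is not broken down here. Compound 4, `CC(C)c1ccc2c(CCC/C=N/N=C(\S)Nc3ccc(Cl)cc3)cc(C(=O)O)c-2cc1`, has not yet been measured; it carries the same change as compound 2, (chloro in place of hydrogen on an aromatic carbon). Since the measured pair shows no readable size, compound 4 is expected to stay close to compound 3, with an estimated step of a 1.2-fold lower number from compound 3 to compound 4 (0.07 log units; within the scatter). Compound 4 is therefore estimated at 500000 nM, between 150000 nM and 1500000 nM.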

Compound 4, half-maximal inhibitory concentration: > 100000 nM
Compound 4: a limit, no number; the forecaster's own chance of this, stated with the estimate: 35%; the middle value does not contradict the limit.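

No step can be read from compound 3 to compound 4, because compound 4 gives only a limit and no number: the limit of > 100000 nM in this assay, at which 3 of the 4 values shown sit. On these data alone, whether chloro in place of hydrogen changes inhibition at all remains open.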